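This account rests on a few compounds, and the source may have more. Where it says the series, first, only, none or still open, it means among the compounds named here.

In an ADME assay on HL-60 cells (Homo sapiens) for cytotoxicity, read by MTT assay, with a stated time of 24 h (a higher number here means a weaker inhibitor, a lower number a stronger inhibitor), compound 1 `CC(C)CCCN(C)Cc1ccc(C2=CCCN(C)C2)cc1` gives > 50000 nM, which is a limit of the assay and not a number. Compound 2 `CC(C)CN(C)Cc1ccc(C2CCCN(C)C2)cc1` gives > 50000 nM, again only a limit. Compound 2 therefore has no numerical value and stands at the limit of > 50000 nM in this assay, at which 2 of the 2 values shown sit.

The next compound, compound 3 `CN(Cc1ccc(Cl)cc1)Cc1ccc(C2CCCN(C)C2)cc1`, carries one change from compound 2: 4-chlorophenyl in place of isopropyl on a saturated chain carbon bound to an amine nitrogen. This places 4-chlorophenyl in place of isopropyl on a saturated chain carbon bound to an amine nitrogen. For the measured compounds named here, no measured step shows the effect of such a change. A modest shift towards stronger inhibition is expected, an at least 1.2-fold lower number from compound 2 to compound 3 (0.09 log units; that floor lies within the scatter), although a result within the scatter would not be surprising. Another reading reported only as a limit is also quite possible. Compound 3 is estimated at 40000 nM, with an expected range from 15000 nM to 80000 nM.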

Compound 3, half-maximal inhibitory concentration: > 50000 nM
Compound 3 was reported as a limit; the forecaster's own chance of this, stated with the estimate: 60%; middle value at least 1.2-fold (0.09 log units) from the limit.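

In this assay compound 3 gives > 50000 nM, again a limit and not a number, so no step can be read from compound 2 to compound 3: the limit of > 50000 nM in this assay, at which 3 of the 3 values shown sit.

The compounds shown leave open whether 4-chlorophenyl in place of isopropyl shifts the read-out at all, and at what concentration any of them would reach half-maximal inhibition.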